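Series notes: cytotoxicity on switching the distal aryl group

The source may hold more compounds than are shown below. What is called first, only, known or untested is meant among the compounds shown, and "the series" means these compounds.

Compound 1 `CCOC(=O)CCCCCOc1cccc(CN(C(=O)c2ccc(-c3ccc4[nH]ccc4c3)cc2)C(C)C)c1` and compound 2 `CCOC(=O)CCCCCOc1cccc(CN(C(=O)c2ccc(-c3ccc(Cl)c(Cl)c3)cc2)C(C)C)c1` share a core and differ only in the aryl group on one aromatic carbon. In an ADME assay on HEK293 cells (Homo sapiens) for cytotoxicity, read by CellTiter-Glo and resazurin assay, with a stated time of 72 h (on this read-out higher numbers stand for an effect only at larger amounts of compound and lower numbers for an effect already at smaller amounts), compound 1 reaches only the limit of the assay, > 26000 nM. In this assay compound 2 likewise reaches only the limit, > 26000 nM. The step from compound 1 to compound 2, a step that the two limits leave unreadable from compound 1 to compound 2, therefore cannot be read; both values sit at the limit of > 26000 nM in this assay, at which 2 of the 2 values shown sit. On the numbers shown, compound 2 stands at a limit and not at a number, and the one further value shown is a limit as well.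

Compound 3 `CCOC(=O)CCCCCOc1cccc(CN(C(=O)c2ccc(-c3cccc(S(C)(=O)=O)c3)cc2)C(C)C)c1` carries the change (3-(methylsulfonyl)phenyl in place of 3,4-dichlorophenyl on an aromatic carbon). Among the compounds with values here, no measured step bears directly on this replacement; the only step, from compound 1 to compound 2, is unreadable, and both neighbours sit at the same limit. No step beyond the scatter in this assay is therefore expected from compound 2 to compound 3, and the estimated step is a step that the limit leaves unreadable from compound 2 to compound 3. For compound 3 the expected value in this assay is 40000 nM, with an estimated range from 20000 nM to 120000 nM, most likely reported again as a limit.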

Compound 3, half-maximal effective concentration: > 26000 nM
Compound 3 ended at the assay's limit; the forecaster's own chance of this, stated with the estimate: 85%; the middle value lies beyond the limit too.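

In this assay, no new step can be read from compound 1 to compound 3 or from compound 2 to compound 3, since all three compounds stand at a limit and not at a number: the limit of > 26000 nM in this assay, at which 3 of the 3 values shown sit.

The compounds shown leave open whether the aryl group on the shared core changes cytotoxicity at all, and at what concentration any of the three would give a measurable half-maximal effect.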